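Aryl amine variation on the shared sulfonyl core

The source may report more compounds than this note shows. Statements on the series, on what has been measured and on what is new or still open speak of the compounds shown alone.

Measured so far in a functional assay on PC-3 cells (Homo sapiens) for cytotoxicity, read by MTT assay, with a stated time of 72 h; on this read-out lower numbers stand for stronger inhibition and higher numbers for weaker inhibition:
Compound 1 `COc1ccc(Nc2nc3ccccc3nc2S(=O)(=O)c2ccc(C)cc2)cc1` gives > 50000 nM, which is a limit of the assay and not a number.
Compound 2 `Cc1ccc(S(=O)(=O)c2nc3ccccc3nc2Nc2cccc(N)c2)cc1` gives 2000 nM.

Among the compounds with values here, compound 2 therefore holds the only number in this assay; the value of compound 1 is a limit (the limit of > 50000 nM in this assay, at which 1 of the 2 values shown sits). Within the data shown here, the step of an at least 25-fold lower number from compound 1 to compound 2 (1.39 log units; beyond the scatter) is the one measured step, and it shows that exchanging the aryl group on the nitrogen attached to the shared core moves the read-out strongly. Compound 3 `Cc1ccc(S(=O)(=O)c2nc3ccccc3nc2Nc2ccc(F)cc2)cc1` carries the change (4-fluorophenyl in place of 3-aminophenyl on a nitrogen on an aromatic ring). The entering 4-fluorophenyl, like the 4-methoxyphenyl of compound 1, has no free amino group, so the measured step of an at least 25-fold lower number from compound 1 to compound 2 (1.39 log units; beyond the scatter) bears on it in reverse: the amino group that entered with compound 2 leaves again. A large step upward in this assay is therefore expected, estimated as a 10-fold higher number from compound 2 to compound 3 (1.00 log units; beyond the scatter). It is also expected that, as for compound 1 (the limit of > 50000 nM in this assay, at which 1 of the 2 values shown sits), only a limit may be reported. For compound 3 the estimate in this assay is 20000 nM, with a range from 5000 nM to 50000 nM.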

Compound 3, half-maximal inhibitory concentration: 13100 nM
Estimate against measurement, compound 3: 1.5-fold (0.18 log units) above; low and high end bracket the measured number.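

In this assay, the position on a nitrogen on an aromatic ring keeps a measurable value without a free amino group, although 4-fluorophenyl in place of 3-aminophenyl costs activity: a 6.6-fold higher number from compound 2 to compound 3 (0.82 log units; beyond the scatter). Loss of the amino group therefore does not by itself send a compound to the limit, since fluoro in place of methoxy on an aromatic carbon also moves the read-out, with an at least 3.8-fold lower number from compound 1 to compound 3 (0.58 log units; beyond the scatter). Compound 1 remains a limit of the assay and not a number, and the size of that second step stays open on one side: the limit of > 50000 nM in this assay, at which 1 of the 3 values shown sits.

Going by these compounds, whether the difference between compound 2 and compound 3 belongs to the amino group itself or to the fluoro group that replaces it stays open, as the two aryl groups share no substituent. An unsubstituted phenyl, or an aryl ring carrying a hydroxyl or a dimethylamino group, on the same nitrogen would bear on that question, and the 4-methylphenyl sulfonyl part of the shared core stays the same throughout the compounds shown.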